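A few compounds are considered here, and "the series" means these few. Any claim that something is new, unique, unknown or untested is made for them only; others in the source may bear on it.

In an ADME assay on KB cells (Homo sapiens) for cytotoxicity, read by MTT assay, with a stated time of 72 h (a lower number here means that less compound is tolerated, a higher number that more compound is tolerated), compound 1 `COc1ccnc(-c2csc(Nc3ccc(Cl)cn3)n2)c1` gives 62800 nM and compound 2 `Clc1ccc(Nc2nc(-c3ccccn3)c(Cl)s2)nc1` gives 326000 nM as its half-maximal cytotoxic concentration. Compound 2 stands highest of the two, and its gap to compound 1 lies beyond the usual scatter of repeated measurements. Among the compounds with values here, no measured pair differs in just one place, so the size of a single change cannot be read directly from these data.

Compound 3 `COc1ccnc(-c2nc(Nc3ccc(Cl)cn3)sc2Cl)c1` comes from compound 2 by one change, methoxy in place of hydrogen on an aromatic carbon, opposite the ring nitrogen (methoxy in place of hydrogen on an aromatic carbon). Compound 1 also carries a methoxy and gives 62800 nM in this assay so a moderate move towards lower numbers, beyond the scatter, is expected for this change. Within the data shown here, the estimated move is (a 3.0-fold lower number from compound 2 to compound 3 (0.47 log units; beyond the scatter)) and it remains uncertain, as no measured step isolates the methoxy. Compound 3 is expected to give about 110000 nM in this assay (estimated range from 35000 nM to 340000 nM).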

Compound 3, half-maximal cytotoxic concentration: 15000 nM
Beside the measured number, compound 3's estimate is 7.3-fold (0.87 log units) above it; the whole stated range lies above it.
By their numbers in this assay, from the lowest: compound 3; then compound 1; then compound 2.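

In this assay, within the data shown here, the methoxy opposite the ring nitrogen now has a measured step of its own, a 22-fold lower number from compound 2 to compound 3 (1.34 log units; beyond the scatter), where the earlier compounds isolated no single change. Compound 3 also gives the second single change, chloro in place of hydrogen on an aromatic carbon, with a 4.2-fold lower number from compound 1 to compound 3 (0.62 log units; beyond the scatter), so on the shared core each of the two groups, added to a compound that already carries the other, goes with less compound being tolerated, the methoxy step being printed as large and the chloro step as modest. The data hold no measurement that accounts for either step.

How the methoxy step would look on a core that carries no chloro stays open, so the compounds shown cannot tell whether the two steps simply add up or depend on each other. Also open, going by these compounds, is whether another group opposite the ring nitrogen, such as ethoxy, a hydroxyl or an amine, would go with a step of similar size, or whether the move belongs to the methoxy alone.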